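Adding piperidin-1-yl to the butyl chain of compound 3

The compounds below may be only part of what the source reports. "The series", "measured", "known", "first", "only" and "open" are said of these compounds alone.

Three compounds share one core and differ in the chain on an aromatic nitrogen. In a functional assay on cells (Homo sapiens) for antiproliferative activity, read by MTT assay, with a stated time of 48 h (on this read-out lower numbers stand for stronger inhibition and higher numbers for weaker inhibition), compound 1 (`CN(C)CCn1c(N)c(-c2nc3ccccc3[nH]2)c2nc(C#N)c(C#N)nc21`) gives 43500 nM and compound 2 (`CN1CCN(CCn2c(N)c(-c3nc4ccccc4[nH]3)c3nc(C#N)c(C#N)nc32)CC1`) gives 9110 nM as measured numbers. Compound 3 (`CCCCn1c(N)c(-c2nc3ccccc3[nH]2)c2nc(C#N)c(C#N)nc21`) stands at > 50000 nM and that is a limit of the assay, not a number.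

Compound 4 (`N#Cc1nc2c(-c3nc4ccccc4[nH]3)c(N)n(CCCN3CCCCC3)c2nc1C#N`) keeps the core and alters the chain. The change is piperidin-1-yl in place of methyl on a saturated chain carbon, three bonds along the chain from an aromatic nitrogen and, read another way, butyl gives way to 3-(piperidin-1-yl)propyl.

Compound 2 offers the main clue: ethyl in place of 4-methylpiperazin-1-yl meant an at least 5.4-fold higher number from compound 2 to compound 3 (0.73 log units; beyond the scatter) and so a lower number is expected for compound 4. Compound 1 goes against this pattern, since ethyl in place of dimethylamino meant an at least 1.1-fold higher number from compound 1 to compound 3 (0.06 log units; that floor lies within the scatter) and that floor lies within the scatter. Between the two amine-tipped chains, a 4.8-fold lower number from compound 1 to compound 2 (0.68 log units; beyond the scatter) shows that the choice of end group matters. Within the data shown here, no measured step tests the longer link in compound 4, so the expectation stays loose. The estimated change is an at least 3.3-fold lower number from compound 3 to compound 4 (0.52 log units; beyond the scatter) in this assay with real doubt about its size. For compound 4 the estimated value is 15000 nM with an expected range from 5000 nM to 45000 nM in this test.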

Compound 4, half-maximal inhibitory concentration: 6230 nM
For compound 4 the middle estimate is 2.4-fold (0.38 log units) above the measured one, and the stated range covers the measured number.
By their numbers in this assay, from the lowest: compounds 4 and 2 (each within the scatter of the next); then compound 1. At a limit, above all of these: compound 3.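

In this assay, putting piperidin-1-yl on a saturated chain carbon, three bonds along the chain from an aromatic nitrogen, turns the unmeasurable butyl compound into one with a real number, giving an at least 8.0-fold lower number from compound 3 to compound 4 (0.90 log units; beyond the scatter). Compound 3 stands only at a limit of the assay, not at a number, so that step is a floor: the limit of > 50000 nM in this assay, at which 1 of the 4 values shown sits. The result also shows that a ring-bearing amine on the longer chain can clearly improve on the dimethylamino chain, with a 7.0-fold lower number from compound 1 to compound 4 (0.84 log units; beyond the scatter), while a 1.5-fold lower number from compound 2 to compound 4 (0.17 log units; within the scatter) leaves compound 2 and compound 4 indistinguishable, so the 3-(piperidin-1-yl)propyl and 4-methylpiperazin-1-yl chains cannot be ranked in this assay.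

The chain of compound 4 differs from those of compound 1 and compound 2 in both its end group and its length, so the compounds shown cannot separate these two contributions; a 2-(piperidin-1-yl)ethyl chain or a 3-(dimethylamino)propyl chain would help to do so. They also leave open how a morpholin-4-yl or pyrrolidin-1-yl end group, or a chain longer than 3-(piperidin-1-yl)propyl, would read in this assay.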